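Metabolic stability notes: methyl for hydrogen on the fused ring

The source may report more compounds than this note shows. Statements on the series, on what has been measured and on what is new or still open speak of the compounds shown alone.

Measured compounds:
compound 1 `CCc1cn2c(C)c([C@H](OC(C)(C)C)C(=O)O)c(N3CCC(C)(C)CC3)c(-c3ccc(OCCc4ccc(F)cc4)cc3)c2n1`: > 2 h
compound 2 `Cc1c([C@H](OC(C)(C)C)C(=O)O)c(N2CCC(C)(C)CC2)c(-c2ccc(OCCc3ccc(F)cc3)cc2)c2ncnn12`: > 2 h

In an ADME assay on microsomes from liver (Rattus norvegicus) for metabolic stability (a lower number here means that the compound disappears faster, a higher number that the compound lasts longer), compound 1 reaches only a limit, > 2 h. In this assay compound 2 likewise reaches only a limit, > 2 h. Compound 2 thus stands at the limit of > 2 h in this assay, at which 2 of the 2 values shown sit, so no ordering among the two is possible. Compound 3 `Cc1nc2c(-c3ccc(OCCc4ccc(F)cc4)cc3)c(N3CCC(C)(C)CC3)c([C@H](OC(C)(C)C)C(=O)O)c(C)n2n1` differs from compound 2 by methyl in place of hydrogen on an aromatic carbon. Among the compounds with values here, no measured step covers this change; the expectation is a step no larger than the scatter in either direction, a step that the limit leaves unreadable from compound 2 to compound 3. Compound 3 is estimated at 3 h, with a range of 1.2 h to 8 h.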

Compound 3, half-life: > 2 h
Compound 3 ended at the assay's limit; the forecaster's own chance of this, stated with the estimate: 70%; the middle value lies beyond the limit too.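

Compound 2 and compound 3 both sit at a limit in this assay, so no step can be read between them: the limit of > 2 h in this assay, at which 3 of the 3 values shown sit.

From the compounds shown here alone, how far methyl in place of hydrogen on an aromatic carbon shifts the half-life stays open, as does any ordering among compound 1, compound 2 and compound 3.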